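Methyl additions in a phenoxyacetamide series

The source may report more compounds than this note shows. Statements on the series, on what has been measured and on what is new or still open speak of the compounds shown alone.

Measured compounds:
compound 1, `CCN(Cc1cccs1)C(=O)COc1ccccc1`: 1400 nM
compound 2, `Cc1ccc(OCC(=O)N(Cc2cccs2)c2c(C)n[nH]c2C)cc1`: 0.3 nM
compound 3, `Cc1ccc(OCC(=O)N(Cc2cccs2)c2c[nH]nc2C)cc1`: 0.4 nM

In an assay on HEK293 cells for agonist activity at transient receptor potential cation channel subfamily M member 8 (Homo sapiens), read by fluorescence and calcium flux, with a stated time of 15 min (a higher number here means that more compound is needed for the effect, a lower number that less compound is needed), compound 1 gives 1400 nM, the highest of the three numbers. Compound 3 gives 0.4 nM, and compound 2 gives 0.3 nM. The difference between the core of compound 1 and the core of compound 3 is not broken down here.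

Between compound 3 and compound 2 the change is methyl in place of hydrogen on an aromatic carbon, and the step it made is a 1.3-fold lower number from compound 3 to compound 2 (0.12 log units; within the scatter).

Compound 4, `CCN(Cc1cccs1)C(=O)COc1ccccc1C`, is not yet measured. It differs from compound 1 by methyl in place of hydrogen on an aromatic carbon. This is the same kind of change as from compound 3 to compound 2, not the same: there the methyl enters on a five-membered aromatic ring with 2 nitrogen, next to the ring nitrogen and next to the ring atom that bears a large group; here it enters on a six-membered aromatic ring of carbon only, ortho to a large group. For the measured compounds named here, only that one earlier example of the change exists, on a different core, so the expectation rests on it alone. Given that a 1.3-fold lower number from compound 3 to compound 2 (0.12 log units; within the scatter) stayed within the scatter, the expected step is likewise small, a 1.3-fold lower number from compound 1 to compound 4 (0.10 log units; within the scatter). Compound 4 is expected to give 1100 nM in this assay, between 300 nM and 4000 nM.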

Compound 4, half-maximal effective concentration: 192 nM
The estimate for compound 4 lay 5.7-fold (0.76 log units) above the measured number, outside the stated range (below it).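

On the core of compound 1, methyl in place of hydrogen on an aromatic carbon gave a 7.3-fold lower number from compound 1 to compound 4 (0.86 log units; beyond the scatter) in this assay when placed on a six-membered aromatic ring of carbon only. The two available cases differ both in the core and in the ring that takes the methyl, and the data do not separate these two differences; two cases also give no rule for the series. What they do show is that the size of the step measured on one core did not carry over to the other: the same change on two cores in this assay, a 1.3-fold lower number (0.12 log units; within the scatter) from compound 3 to compound 2 and a 7.3-fold lower number (0.86 log units; beyond the scatter) from compound 1 to compound 4, 5.5-fold (0.74 log units) apart, beyond the scatter of two such steps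

Left open is whether another group in the same place, such as methoxy, chlorine or an amine, moves the number as methyl does on the core of compound 1. Only one place on that ring is shown for this change on that core, and whether a methyl elsewhere on the ring gives a step of like size also remains open.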